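Working notes: adding bromo to compound 3

The source may report more compounds than this note shows. Statements on the series, on what has been measured and on what is new or still open speak of the compounds shown alone.

Measured so far in an ADME assay on HEK293 cells (Homo sapiens) for cytotoxicity, read by reporter gene assay and resazurin assay, with a stated time of 48 h (on this read-out higher numbers stand for lower toxicity in this test and lower numbers for higher toxicity in this test), as follows
- compound 1 `O=C(Nc1cccc(Cl)c1)c1cc(Br)cc(Br)c1O` gives 18000 nM
- compound 2 `COc1ccc(Br)cc1C(=O)Nc1ccc(Sc2nc3ccccc3s2)cc1` gives > 100000 nM as a limit
- compound 3 `O=C(Nc1ccc(Sc2nc3ccccc3s2)cc1)c1ccccc1` gives > 100000 nM as a limit

Compound 3 stands at > 100000 nM as a limit and not as a number. That position is the limit of > 100000 nM in this assay, at which 2 of the 3 values shown sit, and nothing finer can be read there. Compound 4 `O=C(Nc1ccc(Sc2nc3ccccc3s2)cc1)c1cccc(Br)c1` is phenyl to 3-bromophenyl on the same core, with bromo in place of hydrogen on an aromatic carbon, meta to a large group (bromo in place of hydrogen on an aromatic carbon).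

Within the data shown here, the one measured step that bears on this is a step that the two limits leave unreadable from compound 2 to compound 3 and it supplies no size. Compound 2 also carries a bromo, and its > 100000 nM is a limit. Among the measured compounds shown here, compound 1 at 18000 nM is the only number in this assay and also carries bromo, but no measured step joins it to compound 3, so it serves only as a caution toward lower values.

No step beyond the scatter is therefore expected in this assay and any movement that appears is expected toward lower numbers. The expected change is a number no higher from compound 3 to compound 4 (the limit leaves the size open) and this is only an estimate. Compound 4 is estimated at 100000 nM with an expected range from 40000 nM to 200000 nM and a report as a limit is the likeliest outcome.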

Compound 4, half-maximal cytotoxic concentration: 74000 nM
For compound 4 the middle estimate is 1.4-fold (0.13 log units) above the measured one; low and high end bracket the measured number.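

In this assay, among these compounds, compound 4 gives 74000 nM, the only number on the shared core so far, so this core with bromo on an aromatic carbon, meta to a large group, can be read as a value rather than a limit. Bromo in place of hydrogen gives an at least 1.3-fold lower number from compound 3 to compound 4 (0.13 log units; that floor lies within the scatter), and hydrogen in place of methoxy on an aromatic carbon gives an at least 1.3-fold lower number from compound 2 to compound 4 (0.13 log units; that floor lies within the scatter); each is only a floor, set against a limit, so neither shows a change beyond the scatter and the true sizes stay open. The step between the other two compounds on this core cannot be read, and the reading there remains capped: the limit of > 100000 nM in this assay, at which 2 of the 4 values shown sit.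

As far as these compounds go, whether bromo elsewhere on this ring would give a number or a limit in this assay remains open, as does how much of the true step belongs to this position rather than to bromo itself. Also open, from the compounds shown here alone, is how an amine or a carboxylic acid in place of the bromo would read on the same core.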